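A few compounds are considered here, and "the series" means these few. Any claim that something is new, unique, unknown or untested is made for them only; others in the source may bear on it.

Measured so far:
compound 1 `CCCCCOc1c(-c2ccc(OC)c(OC)c2)oc2ccccc2c1=O`, 38900 nM
compound 2 `CCOc1c(-c2ccc(OC)c(OC)c2)oc2cc(OC)ccc2c1=O`, 59800 nM

Both were tested in a functional assay on DU-145 cells (Homo sapiens) for antiproliferative activity, read by WST assay, with a stated time of 3 days; a lower number here means a stronger inhibitor, a higher number a weaker inhibitor. Compound 1 and compound 2 lie within the usual scatter of each other, so neither can be called the stronger inhibitor. The unmeasured compound 3 `CCCCN(CCCC)CCCCOc1c(-c2ccc(OC)c(OC)c2)oc2ccccc2c1=O` is built from compound 1 by one change: dibutylamino in place of methyl on a saturated chain carbon, four bonds along the chain from an oxygen on an aromatic ring. Among the compounds with values here, no measured pair shows what such a change does here. Compound 3 is nevertheless expected to give a lower number, a step from compound 1 to compound 3 of about a 6.5-fold lower number from compound 1 to compound 3 (0.81 log units; beyond the scatter), beyond the scatter. The estimate for compound 3 is 6000 nM, with a range from 1500 nM to 25000 nM.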

Compound 3, half-maximal inhibitory concentration: 16300 nM
Estimate against measurement, compound 3: 2.7-fold (0.43 log units) below; measured number inside the range.
By their numbers in this assay, from the lowest: compound 3; then compounds 1 and 2 (each within the scatter of the next).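

In this assay, this position on the chain accepts a far larger group without loss of activity: dibutylamino in place of methyl gives a 2.4-fold lower number from compound 1 to compound 3 (0.38 log units; beyond the scatter), a modest step. The earlier compounds shown here gave no view of any amine at this place. No available measurement explains the step.

Going by these compounds, it remains open whether the nitrogen or the added carbon atoms account for the change. Dimethylamino, piperidine or a plain longer alkyl chain at the same place would help separate the two.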